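The source may hold more compounds than are shown below. What is called first, only, known or untested is meant among the compounds shown, and "the series" means these compounds.

Three compounds share one core and were examined in a functional assay on MCF7 cells (Homo sapiens) for inhibition, read by MTT assay, with a stated time of 48 h, tested at 30 ug/mL; a lower number here means less inhibition of growth, a higher number more inhibition of growth at the concentration tested. Compound 3 `O=c1cc(-c2ccccc2)oc2ccc(N3COc4ccccc4C3)cc12` gives 68.5% in this assay. Compound 1 `Cc1cc(C)c2c(c1)CN(c1ccc3c(=O)cc(-c4ccccc4)oc3c1)CO2` gives 26.8%. Compound 2 `O=c1cc(-c2ccccc2)oc2cc(N3COc4c(cccc4[N+](=O)[O-])C3)ccc12` gives 5.65%, the lowest of the three numbers; compound 1 lies above it by a margin beyond the scatter, and compound 3 lies higher still, also beyond the scatter.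

Compound 4 `Cc1cccc2c1OCN(c1ccc3c(=O)cc(-c4ccccc4)oc3c1)C2` has not yet been measured. It differs from compound 2 in one place: methyl in place of nitro on an aromatic carbon. Going by the values given here, no measured pair shows this exact change, so the size of the step can only be estimated from the other two compounds. An upward step is expected from compound 2 to compound 4, and one beyond the scatter, because compound 1 with its methyl groups gives 26.8% and because compound 3 without any such group gives 68.5%. For compound 4 in this assay a value of about 32% is estimated, within a range from 12% to 60%, an expected step of a number 26.4 percentage points higher from compound 2 to compound 4 (beyond the scatter).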

Compound 4, percent growth inhibition at one concentration: 57.8%
The estimate for compound 4 lay 25.8 percentage points below the measured number, within the range that was stated.
By their numbers in this assay, from the lowest: compound 2; then compound 1; then compound 4; then compound 3.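

In this assay, methyl in place of nitro on this aromatic carbon gives a number 52.2 percentage points higher from compound 2 to compound 4 (beyond the scatter), a direct reading of this change, and shows that the group held at this position can move growth inhibition by a large margin. Hydrogen in place of methyl on an aromatic carbon gives a number 31 percentage points higher from compound 1 to compound 4 (beyond the scatter), so the gain seen with compound 4 does not extend to every added methyl: compound 1, with its extra methyl, stands lower. The data shown offer no measurement that explains either step.

Going by these compounds, what an amine or a chlorine on this aromatic carbon would give remains open. On these data alone, compound 3 differs from these compounds in more than one place, so the effect of hydrogen at this position in the core of compound 4 also stays unknown.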